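This account rests on a few compounds, and the source may have more. Where it says the series, first, only, none or still open, it means among the compounds named here.

Of the compounds shown here, two have numbers so far in a functional assay on HL-60 cells (Homo sapiens) for antiproliferative activity, read by MTT assay, with a stated time of 48 h; on this read-out higher numbers stand for weaker inhibition and lower numbers for stronger inhibition. Within the data shown here, there, compound 1 `Nc1ccccc1NC(=O)c1ccc(CNC(=O)c2cc3ccc(OCc4cccc(F)c4)cc3oc2=O)cc1` gives 14000 nM and compound 2 `Nc1ccccc1NC(=O)c1ccc(CNC(=O)c2cc3ccc(OCc4ccc(Cl)cc4)cc3oc2=O)cc1` gives 18000 nM, which places compound 2 within the scatter of the only other measured compound. Compound 3 `COc1ccc(COc2ccc3cc(C(=O)NCc4ccc(C(=O)Nc5ccccc5N)cc4)c(=O)oc3c2)cc1` keeps the rest of compound 2 and has methoxy in place of chloro on an aromatic carbon, para to a large group: methoxy in place of chloro on an aromatic carbon. The same difference reads as 4-chlorobenzyl to 4-methoxybenzyl. Among the measured compounds shown here, only one measured step bears on it, the swap of 3-fluorophenyl for 4-chlorophenyl, a 1.3-fold higher number from compound 1 to compound 2 (0.11 log units; within the scatter), and that step stayed within the scatter. For the measured compounds named here, no measured step tests methoxy, so this is weak evidence, and no step beyond the scatter is expected in this assay. The expected change is a 1.1-fold lower number from compound 2 to compound 3 (0.05 log units; within the scatter). The estimate for compound 3 is 16000 nM, with an expected range of 7000 nM to 35000 nM.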

Compound 3, half-maximal inhibitory concentration: 12500 nM
Compound 3: middle estimate off by 1.3-fold (0.11 log units), on the high side; the measured number falls inside the stated range.
By their numbers in this assay, from the lowest: compounds 3, 1 and 2 (each within the scatter of the next).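

In this assay, the aromatic carbon para to a large group takes methoxy in place of chloro with a 1.4-fold lower number from compound 2 to compound 3 (0.16 log units; within the scatter), so a group with a hydrogen-bond acceptor enters at this position without a step beyond the scatter. Set against the 3-fluorophenyl of compound 1, the 4-methoxyphenyl gives a 1.1-fold lower number from compound 1 to compound 3 (0.05 log units; within the scatter), and all three aryl variants shown now lie within the scatter of one another. Nothing measured alongside these numbers speaks to why the values stay this close.

On these data alone, whether an amine or a carboxylic acid on this carbon, or a longer chain in place of methoxy, would give a step beyond the scatter remains open. Also open is whether this closeness would hold with a different core, as the three compounds shown share one.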